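A few compounds are considered here, and "the series" means these few. Any claim that something is new, unique, unknown or untested is made for them only; others in the source may bear on it.

Series notes. Compound 1 `COc1ccc(-c2cc(C(=O)/C=C/c3ccccc3)nc3cc(-c4ccccc4)nn23)cc1OC` is the hydrogen-bearing parent of the pair measured so far; in a functional assay on MDA-MB-231 cells (Homo sapiens) for antiproliferative activity, read by MTT assay, with a stated time of 24 h (a lower number here means a stronger inhibitor, a higher number a weaker inhibitor), compound 1 gives 23300 nM. Compound 2 `COc1ccc(-c2cc(C(=O)/C=C/c3ccc(C)cc3)nc3cc(-c4ccccc4)nn23)cc1OC` differs from it by methyl in place of hydrogen on an aromatic carbon, and in this assay compound 2 gives 22600 nM. For the measured compounds named here, the step of a 1.0-fold lower number from compound 1 to compound 2 (0.01 log units; within the scatter) is the only measured step in the set and lies within the scatter, so compound 2 stands at the lowest of the two numbers only nominally, with compound 1 not separated from it beyond the scatter.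

Compound 3 `COc1ccc(C(=O)/C=C/c2cc(-c3ccc(OC)c(OC)c3)n3nc(-c4ccccc4)cc3n2)cc1` is not yet measured. Its difference from compound 2 is 2-((4-methoxyphenyl)carbonyl)ethenyl in place of (2-(4-methylphenyl)ethenyl)carbonyl on an aromatic carbon. Going by the values given here, the one measured step bears on this only loosely: it shows that methyl in place of hydrogen left the number unmoved, but the replacement of (2-(4-methylphenyl)ethenyl)carbonyl by 2-((4-methoxyphenyl)carbonyl)ethenyl has no precedent in the two measured compounds. No step beyond the scatter is therefore expected in this assay, though the uncertainty is wider than for the measured pair. The expected step from compound 2 is a 1.0-fold lower number from compound 2 to compound 3 (0.01 log units; within the scatter). For compound 3 the estimate in this assay is 22000 nM, within 8000 nM to 60000 nM.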

Compound 3, half-maximal inhibitory concentration: 13900 nM
For compound 3 the middle estimate is 1.6-fold (0.20 log units) above the measured one; the range from low to high includes it.
By their numbers in this assay, from the lowest: compounds 3, 2 and 1 (each within the scatter of the next).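

Moving the carbonyl to the far side of the ethenyl link, on the aromatic carbon next to the ring nitrogen, and exchanging the terminal substituent for methoxy gives in this assay a 1.6-fold lower number from compound 2 to compound 3 (0.21 log units; within the scatter) and, against the unsubstituted phenyl side chain, a 1.7-fold lower number from compound 1 to compound 3 (0.22 log units; within the scatter). Neither step lies beyond the scatter, so at this position the reversed 2-((4-methoxyphenyl)carbonyl)ethenyl group, with its extra oxygen and extra hydrogen-bond acceptor, cannot be told apart from either (2-arylethenyl)carbonyl group, a broader exchange than the methyl-for-hydrogen step at the end of the side chain. No measurement here accounts for this outcome or gives a mechanism for it.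

The reversal of the linker and the methoxy group enter together, so the two changes cannot be separated, and a 2-((4-methylphenyl)carbonyl)ethenyl group or a (2-(4-methoxyphenyl)ethenyl)carbonyl group would be needed to split them. Also open, as far as these compounds go, is whether a side chain without the ethenyl link, or one ending in an amine or a carboxylic acid, would produce a step beyond the scatter at this position.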